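The compounds below may be only part of what the source reports. "The series", "measured", "known", "first", "only" and "open" are said of these compounds alone.

Measured compounds:
compound 1 `COc1cccc(COc2ccc3cc(C(=O)/C=C/c4cccc(OC)c4OC)c(=O)oc3c2)c1`: 45500 nM
compound 2 `COc1cc(/C=C/C(=O)c2cc3cc(OCc4ccccc4)ccc3oc2=O)cc(OC)c1OC`: 66400 nM
compound 3 `COc1cc(/C=C/C(=O)c2cc3cc(O)ccc3oc2=O)cc(OC)c1OC`: 8800 nM

All three were run in a functional assay on K562 cells (Homo sapiens) for cytotoxicity, read by MTT assay, with a stated time of 72 h; on this read-out lower numbers stand for stronger inhibition and higher numbers for weaker inhibition. Compound 1 and compound 2 give numbers that lie within the scatter of each other, so no order between them is claimed; compound 3 gives a lower number than either, and its gap to compound 1 lies beyond the scatter. Compound 1 thus stands with compound 2 at the weaker end of the three. Going by the values given here, the only step measured, a 7.5-fold lower number from compound 2 to compound 3 (0.88 log units; beyond the scatter), concerns the oxygen substituent on the core and leaves the aryl group on the double-bonded chain carbon untouched.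

Compound 4 `COc1cccc(COc2ccc3cc(C(=O)/C=C/c4ccc(C)cc4)c(=O)oc3c2)c1` has not been measured. It differs from compound 1 in one place: 4-methylphenyl in place of 2,3-dimethoxyphenyl on a double-bonded chain carbon bound to a double-bonded chain carbon. Among the compounds with values here, no measured pair varies this aryl group, so no step bears on the change and nothing here points to a direction. The expectation is therefore a step within the scatter, a 1.0-fold lower number from compound 1 to compound 4 (0.00 log units; within the scatter), with a wide range on both sides. Compound 4 is expected to give 45000 nM in this assay, with a range from 15000 nM to 130000 nM.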

Compound 4, half-maximal inhibitory concentration: > 50000 nM
Compound 4: only a limit was reported; the forecaster's own chance of this, stated with the estimate: 15%; middle value at least 1.1-fold (0.04 log units) away from the limit.
By their numbers in this assay, from the lowest: compound 3; then compounds 1 and 2 (each within the scatter of the next).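

In this assay, compound 4 gives > 50000 nM, which is a limit and not a number. Going by these compounds alone, replacing 2,3-dimethoxyphenyl with 4-methylphenyl on a double-bonded chain carbon bound to a double-bonded chain carbon gives the first reading on this aryl group, an at least 1.0-fold higher number from compound 1 to compound 4 (0.04 log units; that floor lies within the scatter), and since that floor lies within the scatter, the step gives no measured size and no order between the two compounds. What the change does show is that this 4-methylphenyl group, with the oxygen substituent on the core unchanged, brings no move towards the lower number of compound 3, and the reading sits at the one limit in the series: the limit of > 50000 nM in this assay, at which 1 of the 4 values shown sits.

Still open, as far as these compounds go, is how far the true value of compound 4 lies from that limit, and whether the aryl group has any measurable effect on a core with a free hydroxyl, as in compound 3. Also open, from the compounds shown here alone, is what an amine or a carboxylic acid on this aryl ring would give in this assay.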